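The source may hold more compounds than are shown below. What is called first, only, known or untested is meant among the compounds shown, and "the series" means these compounds.

Compound 1 `Clc1ccc(Cc2nn3cc(-c4ccccc4)nc3s2)cc1` gives in an ADME assay on CCRF-CEM cells (Homo sapiens) for cytotoxicity, with a stated time of 72 h; a higher number here means a weaker inhibitor, a lower number a stronger inhibitor > 250000 nM, a limit of this assay.
Compound 2 `O=Cc1c(-c2ccccc2)nc2sc(Cc3ccc(Cl)cc3)nn12` gives in this assay 22000 nM.
Compound 3 `N#CSc1c(-c2ccc(Cl)cc2)nc2sc(Cc3ccc(Cl)cc3)nn12` gives in this assay 30000 nM.

Compound 3 and compound 2 give numbers that sit within the scatter of each other; compound 1 gives only a limit. Compound 4 `N#CSc1c(-c2ccccc2)nc2sc(Cc3ccc(Cl)cc3)nn12` differs from compound 3 by hydrogen in place of chloro on an aromatic carbon. Among the measured compounds shown here, the one measured step, an at least 11-fold lower number from compound 1 to compound 2 (1.05 log units; beyond the scatter), concerns a different position of the core and does not bear on this change. For the measured compounds named here, no measured step informs the removal of the chloro, so no step beyond the scatter is expected for compound 4. The number for compound 4 is estimated at 45000 nM, with a range of 15000 nM to 150000 nM, which means an expected step of a 1.5-fold higher number from compound 3 to compound 4 (0.18 log units; within the scatter).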

Compound 4, half-maximal inhibitory concentration: 14000 nM
Beside the measured number, compound 4's estimate is 3.2-fold (0.51 log units) above it, outside the stated range (below it).
By their numbers in this assay, from the lowest: compounds 4, 2 and 3 (each within the scatter of the next, the first and the last beyond it). At a limit, above all of these: compound 1.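

Going from 4-chlorophenyl to phenyl gives a 2.1-fold lower number from compound 3 to compound 4 (0.33 log units; beyond the scatter) in this assay and is the first measured effect of a change on this ring. The step of a 1.6-fold lower number from compound 2 to compound 4 (0.20 log units; within the scatter) leaves cyanosulfanyl and formyl on the core's aromatic carbon unseparated. Cyanosulfanyl in place of hydrogen gives an at least 17-fold lower number from compound 1 to compound 4 (1.25 log units; beyond the scatter) as a step read from a limit: the limit of > 250000 nM in this assay, at which 1 of the 4 values shown sits.

As far as these compounds go, whether a methoxy or an amine in place of the chloro moves the number further stays open. So does whether a carboxylic acid or a longer chain on the core's aromatic carbon stays level with cyanosulfanyl and formyl.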